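Fluoro removal on the aryl sulfonamide: cytotoxicity note

The source may report more compounds than this note shows. Statements on the series, on what has been measured and on what is new or still open speak of the compounds shown alone.

Compound 1 `O=C1O[C@H]([C@@H](O)Cn2cc(CNS(=O)(=O)c3ccc(Cl)cc3F)nn2)C(OCc2ccccc2)=C1OCc1ccccc1` is the reference point of the series. In an ADME assay on HFF cells (Homo sapiens) for cytotoxicity, read by MTT assay, with a stated time of 72 h (on this read-out lower numbers stand for stronger inhibition and higher numbers for weaker inhibition), compound 1 gives 20 nM, the lowest of the two numbers at hand. Compound 3 `CC(C)(C)OC(=O)N1CCN(C(=S)SCc2cn(C[C@H](O)[C@H]3OC(=O)C(OCc4ccccc4)=C3OCc3ccccc3)nn2)CC1` gives 60 nM in this assay, a gap that lies beyond the scatter. Compound 2 `O=C1O/C(=C\Cn2cc(-c3ccc(Br)cc3)nn2)C(OCc2ccccc2)=C1OCc1ccccc1` returns only a limit of > 100000 nM in this assay, matching (the limit of > 100000 nM in this assay, at which 1 of the 3 values shown sits). Compound 2 and compound 3 are built differently from compound 1 in more than one place, so no single step can be read between any pair of the measured compounds.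

Compound 4 `O=C1O[C@H]([C@@H](O)Cn2cc(CNS(=O)(=O)c3ccc(Cl)cc3)nn2)C(OCc2ccccc2)=C1OCc1ccccc1` is the one still to be measured. It differs from compound 1 as follows: hydrogen in place of fluoro on an aromatic carbon. Among the compounds with values here, no measured pair isolates this change, so the step must be judged from the change itself, which alters a single aromatic substituent and leaves the rest of the molecule as in compound 1. The expected step from compound 1 to compound 4 is a 1.5-fold higher number from compound 1 to compound 4 (0.18 log units; within the scatter), a weak move not expected to reach beyond the scatter in either direction. For compound 4 the estimate in this assay is 30 nM, with a range from 10 nM to 90 nM.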

Compound 4, half-maximal inhibitory concentration: 20 nM
For compound 4 the middle estimate is 1.5-fold (0.18 log units) above the measured one; low and high end bracket the measured number.
By their numbers in this assay, from the lowest: compounds 1 and 4 (each within the scatter of the next); then compound 3. At a limit, above all of these: compound 2.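

Taking the 4-chloro-2-fluorophenyl group to the 4-chlorophenyl group in this assay gives no change at the digits printed from compound 1 to compound 4 (within the scatter) and is the first step in the series that can be read at a single place, since the earlier compounds differ from one another in more than one place. For this pair, then, the low number in this assay does not depend on the fluoro group on the aromatic carbon ortho to a large group, and hydrogen serves there equally well, with the rest of compound 1 left as it stands. Nothing at hand bears on why the fluoro group can be exchanged for hydrogen without a readable shift in this result.

Still open is how this aromatic carbon responds to a group of a different kind, such as a methoxy group, an amine or a carboxylic acid, since fluoro and hydrogen are the only two substituents shown there. Equally open is whether the chloro group contributes to the number in this assay, as both compound 1 and compound 4 carry it and no matching compound with hydrogen or a methyl group in its place is shown.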